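Swapping the Benzothiazolyl Thioether for a Thiadiazolyl Thioether

The source may report more compounds than this note shows. Statements on the series, on what has been measured and on what is new or still open speak of the compounds shown alone.

Measured so far:
Compound 1, `C#CCSc1nc(Sc2nnnn2CCN(C)C)c(C#N)c(-c2cccc(Cl)c2)n1`, gives 8640 nM in a functional assay on SMMC-7721 cells (Homo sapiens) for antiproliferative activity, read by MTT assay, with a stated time of 72 h; on this read-out higher numbers stand for weaker inhibition and lower numbers for stronger inhibition.
Compound 2, `C#CCSc1nc(Sc2nc3ccccc3s2)c(C#N)c(-c2cc(OC)c(OC)c(OC)c2)n1`, is reported only as a limit, > 20000 nM.
Compound 3, `C=CC(=O)Nc1ccccc1CN(C(=O)Nc1cccc(C(F)(F)F)c1)C1CCN(C(C)CCC)CC1`, gives 16200 nM.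

Compound 2 thus stands at the weak end of the three numbers shown; the figure for compound 2 is the limit of > 20000 nM in this assay, at which 1 of the 3 values shown sits, so no number for it is known, only that it lies beyond the range the assay resolves. For the measured compounds named here, compound 1, the only other member of the same core among the three, gives a measurable though weak value, and compound 3, built on a different scaffold, is also weak.

Compound 4, `C#CCSc1nc(Sc2nncs2)c(C#N)c(-c2cc(OC)c(OC)c(OC)c2)n1`, differs from compound 2 in one place: 1,3,4-thiadiazol-2-yl in place of 1,3-benzothiazol-2-yl on a sulfur. The change shrinks the group on the sulfur from a bicyclic to a single five-membered ring, with the ring composition as counted above.

Going by the values given here, no measured step frames this change, so the expectation rests on the limit of compound 2 and the weak value of compound 1. In this assay a small shift in either direction, or none beyond the scatter, is expected; compound 4 is therefore estimated at 15000 nM, within 5000 nM to 40000 nM, an expected step of an at least 1.3-fold lower number from compound 2 to compound 4 (0.12 log units; that floor lies within the scatter).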

Compound 4, half-maximal inhibitory concentration: 4660 nM
The estimate for compound 4 lay 3.2-fold (0.51 log units) above the measured number, and the stated range ends above it.
By their numbers in this assay, from the lowest: compounds 4, 1 and 3 (each within the scatter of the next, the first and the last beyond it). At a limit, above all of these: compound 2.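

In this assay, for the compounds shown here, the group on this sulfur matters on the shared core: 1,3,4-thiadiazol-2-yl in place of 1,3-benzothiazol-2-yl gives an at least 4.2-fold lower number from compound 2 to compound 4 (0.63 log units; beyond the scatter), the only measured step at this position, which the earlier compounds could not provide. The true size of that step stays open, because compound 2 is reported only as a limit: the limit of > 20000 nM in this assay, at which 1 of the 4 values shown sits.

The change removes the six-membered aromatic ring of carbon and also alters the five-membered aromatic ring, which now holds 3 hetero atoms instead of 2, and this single step cannot separate those two differences.

The compounds shown leave open how other groups on this sulfur would read, such as a plain phenyl, a pyridin-2-yl, or a 1,3,4-thiadiazol-2-yl carrying a methyl or an amine. They also leave open whether the same exchange would give a like step on a compound of this core with a different group elsewhere, as this one pair is all that frames it.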